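The compounds below may be only part of what the source reports. "The series", "measured", "known", "first", "only" and "open" are said of these compounds alone.

Of the compounds shown here, three that share one core have been measured in an ADME assay on microsomes from liver (Mus musculus, strain CD-1) for metabolic stability; on this read-out higher numbers stand for a longer-lived compound and lower numbers for a shorter-lived compound: compound 1 (`Cc1cccc(C(=O)Nc2nc(-c3ccccn3)cs2)c1`) gives 0.112 h, compound 2 (`COc1ccc(C(=O)Nc2nc(-c3ccccn3)cs2)cc1`) gives 0.267 h, and compound 3 (`O=C(Nc1nc(-c2ccccn2)cs1)c1cccc(Br)c1`) gives 0.183 h. Compound 3 sits within the usual scatter of both other compounds, so these numbers do not clearly separate it from either one.

Compound 4 (`O=C(Nc1nc(-c2ccccn2)cs1)c1ccc(Br)cc1`) has the same atoms as compound 3, joined differently, and the difference is 4-bromophenyl in place of 3-bromophenyl on a carbonyl carbon. Put simply, the bromine-bearing ring changes from 3-bromophenyl to 4-bromophenyl on a carbonyl carbon.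

Within the data shown here, only one measured step bears on this part of the molecule: bromo in place of methyl on an aromatic carbon, which gives a 1.6-fold higher number from compound 1 to compound 3 (0.21 log units; within the scatter). That step lies within the scatter, and it swaps one group for another rather than relocating the bromine, so it is only an indirect guide. Among the measured compounds shown here, no measured pair shows what relocating the bromine does, so no direction can be argued, and no change beyond the scatter is expected.

The expected change is a 1.1-fold higher number from compound 3 to compound 4 (0.04 log units; within the scatter). For compound 4 the estimated half-life is 0.2 h, with an expected range of 0.1 h to 0.38 h.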

Compound 4, half-life: 0.113 h
Compound 4: middle estimate off by 1.8-fold (0.25 log units), on the high side, and the stated range covers the measured number.
By their numbers in this assay, from the lowest: compounds 1, 4, 3 and 2 (each within the scatter of the next, the first and the last beyond it).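

Relocating the bromine, with 4-bromophenyl in place of 3-bromophenyl on a carbonyl carbon, gives a 1.6-fold lower number from compound 3 to compound 4 (0.21 log units; within the scatter) in this assay and is the first direct look at this kind of change; the two isomers are not separated by these numbers, although the printed step is as large as the earlier one from methyl to bromo. Replacing 3-methylphenyl with 4-bromophenyl on the same carbonyl carbon gives a 1.0-fold higher number from compound 1 to compound 4 (0.00 log units; within the scatter) and likewise leaves the two compounds within the scatter of each other, so changing both the group and its place on the ring produces no measurable difference here. Among these compounds, the clearest contrast comes from swapping the methoxy group for a bromine, which gives a 2.4-fold lower number from compound 2 to compound 4 (0.37 log units; beyond the scatter) and is the only new step beyond the scatter, though its size is modest and it rests on a single pair.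

The compounds shown leave open whether an amine or a carboxylic acid in place of the bromine would move the half-life beyond the scatter. Nothing available explains why any of these steps has the size it does.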